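The source may report more compounds than this note shows. Statements on the series, on what has been measured and on what is new or still open speak of the compounds shown alone.

Of the compounds shown here, two of one shared core have been tested in an assay on CHO cells for displacement of a labelled ligand from sphingosine 1-phosphate receptor 4 (Homo sapiens) (a higher number here means a weaker inhibitor, a lower number a stronger inhibitor), and both met the same fate. Compound 1, `Cc1cc(CCC(=O)O)ccc1-c1noc(-c2ccc(OC(C)C)c(C#N)c2)n1`, carries a propanoic acid chain and a nitrile on its outer ring. In this assay compound 1 gives > 10000 nM, which is a limit of the measurement rather than a number. Compound 2, `Cc1cc([C@@H]2C[C@H]2C(=O)O)ccc1-c1noc(-c2ccc(OC(C)C)c(C(F)(F)F)c2)n1`, carries a trifluoromethyl group instead of the nitrile and a 2-carboxycyclopropyl group with two defined stereocentres in place of the chain. In this assay compound 2 likewise gives > 10000 nM, again a limit and not a number. Compound 2 therefore stands at the limit of > 10000 nM in this assay, at which 2 of the 2 values shown sit; nothing shown separates it from compound 1.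

Compound 3, `Cc1cc(C(C)CC(=O)O)ccc1-c1noc(-c2ccc(OC(C)C)c(C(F)(F)F)c2)n1`, keeps the trifluoromethyl group and changes the acid-bearing group: 1-(carboxymethyl)ethyl in place of 2-carboxycyclopropyl on an aromatic carbon. Between compound 2 and compound 3 no measured step exists, so the expectation rests only on the limit seen for compound 2. The step is estimated as a step that the limit leaves unreadable from compound 2 to compound 3, which is no change beyond the usual scatter. Compound 3 is expected to give 15000 nM, with a likely range from 3000 nM to 60000 nM.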

Compound 3, half-maximal inhibitory concentration: > 10000 nM
Compound 3: only a limit was reported (the forecaster's own chance of this, stated with the estimate: 75%); the middle value is on the limit's open side.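

Compound 2 and compound 3 both end at a limit of the measurement rather than a number, so no step between them can be read: the limit of > 10000 nM in this assay, at which 3 of the 3 values shown sit.

The three compounds leave open how strongly each one actually inhibits, and whether changing the acid-bearing group or the nitrile or trifluoromethyl group alters that at all.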